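The source may hold more compounds than are shown below. What is called first, only, known or untested is meant among the compounds shown, and "the series" means these compounds.

Measured in an assay for inhibition of kynurenine 3-monooxygenase (Homo sapiens), read by mass spectrometry, with a stated time of 1 h; a higher number here means a weaker inhibitor, a lower number a stronger inhibitor:

compound 1, `Cc1ccc([C@@H](C)Oc2cc3onc(CCC(=O)O)c3cc2Cl)nc1`: 3.16 nM
compound 2, `Cc1ccc([C@@H](C)Oc2cc3oc(=O)n(CCC(=O)O)c3cc2Cl)nc1`: 3.16 nM
compound 3, `C[C@@H](Oc1cc2onc(CCC(=O)O)c2cc1Cl)c1ccc(F)cn1`: 3.16 nM

Compound 2 sits level with compound 1 and compound 3 in this assay; the three values lie within the usual scatter of one another, and no order among them can be read from these digits.

The next compound in the series is compound 4, `C[C@@H](Oc1cc2oc(=O)n(CCC(=O)O)c2cc1Cl)c1ccc(Cl)cn1`. It differs from compound 2 in one place: chloro in place of methyl on an aromatic carbon.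

For the measured compounds named here, one measured step bears on this change. From compound 1 to compound 3 a fluoro replaced a methyl on an aromatic carbon, and the result was no change at the digits printed from compound 1 to compound 3 (within the scatter). That is a halogen in place of the same methyl, though on the core of compound 1 rather than the core of compound 2, and with fluoro rather than chloro. Going by the values given here, no chloro analogue has been measured on either core, so the expectation rests on that single step alone. On that basis a step of no size beyond the scatter is expected in this assay, a 1.0-fold higher number from compound 2 to compound 4 (0.01 log units; within the scatter).

Compound 4 is accordingly estimated at 3.2 nM in this assay, with a range from 1.3 nM to 8 nM.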

Compound 4, half-maximal inhibitory concentration: 3.16 nM
Beside the measured number, compound 4's estimate is 1.0-fold (0.01 log units) above it; the measured number falls inside the stated range.
By their numbers in this assay, from the lowest: compounds 1, 2, 3 and 4 (each within the scatter of the next).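

Working notes: the methyl-to-halogen swap at this place now has a reading with chloro and on the core of compound 2, where 5-methylpyridin-2-yl to 5-chloropyridin-2-yl gives no change at the digits printed from compound 2 to compound 4 (within the scatter) in this assay. Alongside the fluoro swap on the core of compound 1, no change at the digits printed from compound 1 to compound 3 (within the scatter), this means two different halogens on two different cores have now replaced this methyl without a step beyond the scatter, though each step holds for its own core only. Nothing available explains why the reading stays level.

Still open, as far as these compounds go, is whether a methoxy, an amine or a longer chain at this place would give a step beyond the scatter. Also open, from the compounds shown here alone, is how fluoro behaves on the core of compound 2 and chloro on the core of compound 1.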